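Benzyloxy in place of methoxy on a long-chain purinium core

This account rests on a few compounds, and the source may have more. Where it says the series, first, only, none or still open, it means among the compounds named here.

Measured compounds:
- compound 1, `CO/N=c1\[nH]cnc2c1[n+](C/C=C(\C)CC/C=C(/C)CCC=C(C)C)cn2C`: 1230 nM
- compound 2, `CC(C)=CCC/C(C)=C\CC/C(C)=C/C[n+]1cn(C)c2nc[nH]/c(=N\OCc3ccccc3)c21`: 10000 nM
- compound 3, `CO/N=c1\[nH]cnc2c1[n+](C/C=C(\C)CCCC(C)CCCC(C)CCCC(C)C)cn2C`: 7920 nM

All three were tested in a functional assay on CEM/s cells (Homo sapiens) for cytotoxicity; on this read-out lower numbers stand for stronger inhibition and higher numbers for weaker inhibition. Compound 1 gives 1230 nM, compound 2 gives 10000 nM, and compound 3 gives 7920 nM. Compounds 1 and 2 share a core and differ in one place: phenyl in place of hydrogen on a saturated chain carbon bound to an oxygen. That single change brought an 8.1-fold higher number from compound 1 to compound 2 (0.91 log units; beyond the scatter), so the benzyloxy compound inhibits more weakly than its methoxy partner.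

Compound 3 carries a different chain on the shared core; the difference between the two cores is not broken down here. Its number lies close to that of compound 2, within the usual scatter, and well apart from that of compound 1.

Compound 4, `C/C(=C\C[n+]1cn(C)c2nc[nH]/c(=N\OCc3ccccc3)c21)CCCC(C)CCCC(C)CCCC(C)C`, has not yet been measured. It stands to compound 3 exactly as compound 2 stands to compound 1: phenyl in place of hydrogen on a saturated chain carbon bound to an oxygen. Because the same change gave an 8.1-fold higher number from compound 1 to compound 2 (0.91 log units; beyond the scatter), a step of similar direction is expected from compound 3 to compound 4, a 3.8-fold higher number from compound 3 to compound 4 (0.58 log units; beyond the scatter), though a weakly active starting point such as compound 3 leaves room for the assay to report only a limit. For compound 4 the expected value in this assay is therefore 30000 nM, with a plausible range from 8000 nM to 100000 nM.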

Compound 4, half-maximal inhibitory concentration: 6300 nM
For compound 4 the middle estimate is 4.8-fold (0.68 log units) above the measured one; measured number outside the range, below it.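

In this assay, putting benzyloxy in place of methoxy on the core of compound 3 gives a 1.3-fold lower number from compound 3 to compound 4 (0.10 log units; within the scatter), so the two values cannot be told apart in this read-out. Among the compounds shown here, the change that clearly raised the number on the core of compound 1 therefore did not do the same on the core of compound 3, and its effect depends on the core that carries it: the same change on two cores in this assay, an 8.1-fold higher number (0.91 log units; beyond the scatter) from compound 1 to compound 2 and a 1.3-fold lower number (0.10 log units; within the scatter) from compound 3 to compound 4, 10-fold (1.01 log units) apart, beyond the scatter of two such steps This rests on only two pairs of compounds, so it shows that the step cannot simply be carried from one core to the other, but it does not show which feature of the two chains is responsible, nor how the change would behave on any third core.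

The compounds shown leave open whether a group of intermediate size on the oxygen, such as ethoxy, would follow the pattern of compound 2 or that of compound 4. They also leave open how methoxy and benzyloxy would compare on the shared core with a much shorter chain, such as a butyl chain, in place of the chains of compound 1 and compound 3.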